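A few compounds are considered here, and "the series" means these few. Any claim that something is new, unique, unknown or untested is made for them only; others in the source may bear on it.

Measured in an ADME assay on HEK293 cells (Homo sapiens) for cytotoxicity, read by reporter gene assay and resazurin assay, with a stated time of 48 h; on this read-out lower numbers stand for higher toxicity in this test and higher numbers for lower toxicity in this test:
Compound 1 `O=C(Nc1ccc(Sc2nc3ccccc3s2)c(Cl)c1)c1cccc(Br)c1O`: 64000 nM
Compound 2 `COc1c(Br)cc(Br)cc1C(=O)Nc1ccc(Sc2nc3ccccc3s2)c(Cl)c1`: > 100000 nM

Compound 2 reads > 100000 nM in this assay, which is a limit of the assay and not a number. Compound 3 `O=C(Nc1ccc(Sc2nc3ccccc3s2)c(Cl)c1)c1cccc(Br)c1` keeps the shared core and differs from compound 2 at one place: a group of 7 heavy atoms (6 carbon, 1 bromine; one six-membered aromatic ring of carbon only) in place of a group of 10 heavy atoms (7 carbon, 1 oxygen, 2 bromine; one six-membered aromatic ring of carbon only), on a carbonyl carbon. The 3-bromophenyl group stands on the carbonyl carbon whose other neighbour is the amide-type nitrogen. For the measured compounds named here, only one measured step bears on this change, an at least 1.5-fold higher number from compound 1 to compound 2 (0.19 log units; that floor lies within the scatter), and it offers no size beyond the scatter. Going by the values given here, compound 1, at 64000 nM, is the only firm number nearby. No step beyond the scatter is therefore expected in this assay, though a somewhat lower number is possible. The estimate means an at least 1.4-fold lower number from compound 2 to compound 3 (0.15 log units; that floor lies within the scatter), a size expected to stay small. For compound 3 the estimated value is 70000 nM, with an expected range of 30000 nM to 100000 nM.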

Compound 3, half-maximal cytotoxic concentration: > 100000 nM
Compound 3: a limit, no number; the forecaster's own chance of this, stated with the estimate: 40%; middle value at least 1.4-fold (0.15 log units) from the limit.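

In this assay, hydrogen in place of hydroxy on an aromatic carbon gives an at least 1.5-fold higher number from compound 1 to compound 3 (0.19 log units; that floor lies within the scatter). The hydroxy group of compound 1 is thus not needed for a number at this level, but no size beyond the scatter can be claimed for this change. Compound 3 gives a limit of the assay and not a number, so its step from compound 2 cannot be read: the limit of > 100000 nM in this assay, at which 2 of the 3 values shown sit.

On these data alone, it remains open how far the true values of compound 2 and compound 3 lie from that of compound 1, and whether they differ from each other at all. Also open, as far as these compounds go, is whether an amine or a carboxylic acid in place of the hydroxy on that aromatic carbon would give a firm number in this assay.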